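A few compounds are considered here, and "the series" means these few. Any claim that something is new, unique, unknown or untested is made for them only; others in the source may bear on it.

Working notes on the series.

Two compounds have numbers in an assay on isolated protein for binding affinity to 5-hydroxytryptamine receptor 4 (Homo sapiens); on this read-out higher numbers stand for weaker inhibition and lower numbers for stronger inhibition. Compound 1 `CC(=O)N1CCN(CCN2CCC(CNC(=O)c3cccc4[nH]c(C(C)C)nc34)CC2)CC1` gives 5.01 nM in this assay, the lowest of the two numbers shown. Compound 2 `CS(=O)(=O)N1CCN(CC(O)CN2CCC(CNC(=O)c3cccc4[nH]cnc34)CC2)CC1` gives 6.31 nM in this assay; the two values sit within the scatter of each other, so no order between compound 1 and compound 2 can be read from them.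

Compound 3 `CC(=O)N(C)CC(O)CN1CCC(CNC(=O)c2cccc3[nH]c(C(C)C)nc23)CC1` has not been measured in this assay. It is reached from compound 1 by the change (2-(acetyl(methyl)amino)-1-hydroxyethyl in place of (4-acetylpiperazin-1-yl)methyl on a saturated chain carbon bound to an amine nitrogen in a ring). The group that leaves carries one six-membered non-aromatic ring with 2 hetero atoms; the group that enters has no ring and brings 1 hydrogen-bond donor, while the acetyl amide and the count of hydrogen-bond acceptors are kept.

Among the measured compounds shown here, no step between measured compounds exists on which to rest a number. Compound 2 shows that a chain bearing a hydroxyl on the same side of the shared core sits within the scatter of compound 1, so the step from compound 1 to compound 3 is expected to be small, at most a modest weakening, a 1.6-fold higher number from compound 1 to compound 3 (0.20 log units; within the scatter). Compound 3 is expected to give 8 nM in this assay, with a range of 3 nM to 25 nM.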

Compound 3, inhibition constant: 3.98 nM
For compound 3 the middle estimate is 2.0-fold (0.30 log units) above the measured one; low and high end bracket the measured number.
By their numbers in this assay, from the lowest: compounds 3, 1 and 2 (each within the scatter of the next).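

In this assay, putting 2-(acetyl(methyl)amino)-1-hydroxyethyl in place of (4-acetylpiperazin-1-yl)methyl on a saturated chain carbon bound to an amine nitrogen in a ring gives a 1.3-fold lower number from compound 1 to compound 3 (0.10 log units; within the scatter) and so leaves the read-out unresolved from that of the parent. Among the compounds shown here, this is the first direct step at this position, and it shows that the six-membered non-aromatic ring with 2 hetero atoms can leave the core of compound 1 without a change that can be told from the scatter, even as the entering group brings 1 hydrogen-bond donor and keeps the acetyl amide. No measurement at hand speaks to why the two groups read alike.

The compounds shown do not separate the contribution of the hydroxyl from that of the acetyl amide, since both remain in compound 3 and no compound carries one without the other on this core. As far as these compounds go, it also remains open whether this position would tolerate a chain ending in a carboxylic acid or a primary amine, or a longer chain than 3-(acetyl(methyl)amino)-2-hydroxypropyl.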